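Compound 4 against the clearance limit

The source may report more compounds than this note shows. Statements on the series, on what has been measured and on what is new or still open speak of the compounds shown alone.

Compound 3 (`c1cc([C@H]2CC[C@]3(CC2)OOC2(O3)C3CC4CC(C3)CC2C4)ccc1OCCOC1CCNCC1`) gives < 7 mL.min-1.g-1 in an ADME assay on microsomes from liver (Homo sapiens) for metabolic stability, read by LC-MS, tested at 1 uM (on this read-out lower numbers stand for slow clearance and higher numbers for fast clearance), which is a limit of the assay and not a number. Compound 1 (`NCCOCCOc1ccc([C@H]2CC[C@]3(CC2)OOC2(O3)C3CC4CC(C3)CC2C4)cc1`) gives < 7 mL.min-1.g-1, which is also a limit. For the measured compounds named here, compound 2 (`NC(=O)C1CCN(Cc2ccc([C@H]3CC[C@]4(CC3)OOC3(O4)C4CC5CC(C4)CC3C5)cc2)CC1`) gives 10 mL.min-1.g-1, the only true number in the set. Going by the values given here, the series so far is therefore defined by the limit of < 7 mL.min-1.g-1 in this assay, at which 2 of the 3 values shown sit.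

Compound 4 (`CC(C)(N)CCOc1ccc([C@H]2CC[C@]3(CC2)OOC2(O3)C3CC4CC(C3)CC2C4)cc1`) differs from compound 3 by one change: 1-amino-1-methylethyl in place of (piperidin-4-yl)oxy on a saturated chain carbon, two bonds along the chain from an oxygen on an aromatic ring. Cut further out, the same difference reads 2-((piperidin-4-yl)oxy)ethoxy to 3-amino-3-methylbutoxy.

Among the compounds with values here, three measured steps bear on it. The closest is a step that the two limits leave unreadable from compound 1 to compound 3, which also alters the end of the chain on the oxygen, but its size cannot be read. The other two are an at least 1.4-fold higher number from compound 1 to compound 2 (0.15 log units; that floor lies within the scatter) and an at least 1.4-fold lower number from compound 2 to compound 3 (0.15 log units; that floor lies within the scatter). Both are only floors, and both lie within the scatter. None of the three shows a step beyond the scatter, so no such step is expected in this assay, and no direction can be firmly assigned. The estimated step is a number no lower from compound 3 to compound 4 (the limit leaves the size open), and a result at the limit is about as likely as a number. For compound 4 the estimated value is 7 mL.min-1.g-1, with an expected range from 4 mL.min-1.g-1 to 14 mL.min-1.g-1.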

Compound 4, intrinsic clearance in microsomes: < 7 mL.min-1.g-1
Compound 4 gave a limit, no number; the forecaster's own chance of this, stated with the estimate: 55%; the middle value sits exactly at the limit.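

In this assay, compound 4 also gives a limit and not a number, so a chain end with no ring and 4 heavy atoms, 1-amino-1-methylethyl, does as well as far as this read-out can tell as the (piperidin-4-yl)oxy end with its 7 heavy atoms, and the six-membered non-aromatic ring is not required at this place for a result at the limit. For the compounds shown here, the steps to compound 4 from compound 3 and from compound 1 cannot be read, as both ends of each are limits, and the one step that can be read is an at least 1.4-fold lower number from compound 2 to compound 4 (0.15 log units; that floor lies within the scatter), so the comparison with compound 2 gives a floor and no firm direction. The branched amine thus extends the cluster at the floor of the assay: the limit of < 7 mL.min-1.g-1 in this assay, at which 3 of the 4 values shown sit.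

The compounds shown leave open how compounds 1, 3 and 4 rank among themselves, since none of the three has a true number. They also leave open whether a carboxylic acid in place of the amine, or a longer chain on the same oxygen, would give a true number in this assay.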